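Shortening a branched chain on a benzotriazine dioxide core

This account rests on a few compounds, and the source may have more. Where it says the series, first, only, none or still open, it means among the compounds named here.

Two compounds share one core and differ only in the chain attached to the nitrogen. Compound 1 `CCCCCOCNc1n[n+]([O-])c2ccccc2[n+]1[O-]` carries a straight chain; in a functional assay on KB cells (Homo sapiens) for cytotoxicity, read by MTT assay, with a stated time of 72 h (a higher number here means a weaker inhibitor, a lower number a stronger inhibitor), compound 1 gives 39500 nM. Compound 2 `CC(C)CCOCNc1n[n+]([O-])c2ccccc2[n+]1[O-]` carries a branched chain, and in this assay compound 2 gives 5210 nM, the lowest of the two numbers; the step of a 7.6-fold lower number from compound 1 to compound 2 (0.88 log units; beyond the scatter) favoured the branched chain. Compound 3 `CCCCOCNc1n[n+]([O-])c2ccccc2[n+]1[O-]` differs from compound 2 by hydrogen in place of methyl on a saturated chain carbon bound to two saturated chain carbons, which returns to a straight chain, one carbon shorter than in compound 1. Because that earlier step a 7.6-fold lower number from compound 1 to compound 2 (0.88 log units; beyond the scatter) went against the straight chain, a higher number is expected here, a 3.8-fold higher number from compound 2 to compound 3 (0.58 log units; beyond the scatter). Compound 3 is therefore estimated at 20000 nM, within 6000 nM to 60000 nM.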

Compound 3, half-maximal inhibitory concentration: 15200 nM
Compound 3: middle estimate off by 1.3-fold (0.12 log units), on the high side, within the range that was stated.
By their numbers in this assay, from the lowest: compound 2; then compound 3; then compound 1.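

In this assay the result depends on where the methyl is lost: taking it from the branch, isopentyl to butyl, gives a 2.9-fold higher number from compound 2 to compound 3 (0.47 log units; beyond the scatter) while taking it from the end of the straight chain gives a 2.6-fold lower number from compound 1 to compound 3 (0.41 log units; beyond the scatter) for the same swap of hydrogen for methyl. A straight chain as such therefore does not set the number, since its length matters too, and the branched chain of compound 2 still gives the lowest number. Whether a hexyl chain or an amine at the chain end would lower the number stays open, and nothing here explains the differences between these chains.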